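This account rests on a few compounds, and the source may have more. Where it says the series, first, only, none or still open, it means among the compounds named here.

Measured so far in a functional assay on MDA-MB-231 cells (Homo sapiens) for antiproliferative activity, read by MTT assay, with a stated time of 72 h; a lower number here means a stronger inhibitor, a higher number a weaker inhibitor:

- compound 1 `CC1=CC[C@H]2[C@@H]1CC=C(C)[C@@H](CC[C@H]1[C@]3(C)CC[C@H](O)C(C)(C)O[C@H]3CC[C@@]1(C)O)C2(C)C`: > 50000 nM (a limit, not a number)
- compound 2 `CC1=CC[C@H]2[C@@H]1CC=C(C)[C@@H](CCC1=C(C)CC[C@@H]3OC(C)(C)[C@@H](O)CC[C@@]13C)C2(C)C`: > 50000 nM (a limit, not a number)
- compound 3 `CC(=O)O[C@H]1CC[C@]2(C)[C@H](CC[C@@](C)(O)[C@H]2CC[C@@H]2C(C)=CC[C@H]3[C@H](CC[C@]3(C)O)C2(C)C)OC1(C)C`: 38000 nM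

Two of the three readings give no number for potency, as shown by the limit of > 50000 nM in this assay, at which 2 of the 3 values shown sit. Within the data shown here, compound 3, at 38000 nM, is the only compound with a measured number. This makes it the sole numerical reference point in this assay, and it sits at the weak end of what the assay can report.

The next compound to be tested is compound 4 `CC(=O)O[C@H]1CC[C@]2(C)[C@H](CC[C@@](C)(O)[C@H]2CC[C@@H]2C(C)=CC[C@H]3[C@H](CC[C@]3(C)OC(C)=O)C2(C)C)OC1(C)C`. Its change from compound 3 is acetyl in place of hydrogen on an oxygen on a saturated carbon. This is acetyl in place of hydrogen on an oxygen on a saturated carbon, a hydroxy to acetoxy change.

Among the measured compounds shown here, no measured pair isolates this change, so there is no direct precedent for its size or direction. The expectation therefore rests on compound 3 at 38000 nM, and no shift beyond the scatter is expected in this assay. The estimate means a step of a 1.3-fold lower number from compound 3 to compound 4 (0.10 log units; within the scatter), which is expected to stay small. A result reported only as a limit also remains possible. For compound 4 the expected value is 30000 nM, with an estimated range of 12000 nM to 60000 nM.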

Compound 4, half-maximal inhibitory concentration: 26200 nM
The estimate for compound 4 lay 1.1-fold (0.06 log units) above the measured number; low and high end bracket the measured number.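

In this assay, among these compounds, the only pair of measured compounds that differ in one place shows that acetyl in place of hydrogen on an oxygen on a saturated carbon, the hydroxy to acetoxy change, leaves the reading within the scatter: a 1.5-fold lower number from compound 3 to compound 4 (0.16 log units; within the scatter). Among the compounds shown here, the free hydroxy at this position is therefore not required for the reading seen with the series so far, and capping it with acetyl neither adds to nor takes away from it in any way that can be told apart from repeat measurements. The series now has a second real number alongside the limits, which gives this position its first measured comparison: the limit of > 50000 nM in this assay, at which 2 of the 4 values shown sit.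

On these data alone, it remains open whether a longer chain on this oxygen, such as a hexanoyl ester, or an acyl group carrying an amine would move the number beyond the scatter. One pair in this assay also cannot show whether the hydroxy to acetoxy change would behave the same way on other oxygens of the shared core.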